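The source may hold more compounds than are shown below. What is called first, only, known or untested is meant among the compounds shown, and "the series" means these compounds.

Three compounds have been measured in a functional assay on CCRF-CEM cells (Homo sapiens) for cytotoxicity; a higher number here means that more compound is tolerated, a lower number that less compound is tolerated:
compound 1, `O=C1Nc2ccccc2/C1=N\c1nc(NC2CC2)c2ncn(C3C=CC(CO)C3)c2n1`, gives 48000 nM
compound 2, `C/C(=N\c1nc(NC2CC2)c2ncn(C3C=CC(CO)C3)c2n1)c1ccc(O)cc1`, gives 62000 nM
compound 3, `O=[N+]([O-])c1ccccc1/C=N/c1nc(NC2CC2)c2ncn(C3C=CC(CO)C3)c2n1`, gives 13000 nM

Among these three numbers compound 1 holds the second highest. Its nearest neighbour is compound 2, whose number lies within the usual scatter of repeated measurements, so the two cannot be told apart. Its furthest neighbour is compound 3, whose number is lower by more than the scatter, meaning that less of compound 3 is tolerated by the cells than of compound 1.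

Compound 4, `Cc1ccc2c(c1)/C(=N\c1nc(NC3CC3)c3ncn(C4C=CC(CO)C4)c3n1)C(=O)N2`, has not yet been measured. It differs from compound 1 in one place: methyl in place of hydrogen on an aromatic carbon. The newcomer sits on a six-membered aromatic ring of carbon only, part of a fused or bridged system of two rings, in the part of compound 1 that hangs off the shared core. For the measured compounds named here, no two of the measured compounds differ from each other in a single place, so no measured step of this kind is available to lean on. A change this small is expected to move the number in this assay by no more than the scatter, in no particular direction.

Compound 4 is therefore estimated at about 45000 nM, with a likely range from 20000 nM to 100000 nM. The expected step of a 1.1-fold lower number from compound 1 to compound 4 (0.03 log units; within the scatter) that this estimate means should stay within the scatter.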

Compound 4, half-maximal cytotoxic concentration: 78000 nM
The estimate for compound 4 lay 1.7-fold (0.24 log units) below the measured number; low and high end bracket the measured number.
By their numbers in this assay, from the lowest: compound 3; then compounds 1, 2 and 4 (each within the scatter of the next).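

For the compounds shown here, this is the first step between two compounds that differ in one place in this assay, and it gives a direct reading of this position. Methyl in place of hydrogen on an aromatic carbon of the six-membered aromatic ring of carbon only gives a 1.6-fold higher number from compound 1 to compound 4 (0.21 log units; within the scatter), so compound 1 and compound 4 cannot be told apart, and at this position on the part hanging off the shared core, the added methyl produces no change that can be distinguished from the scatter. No measurement is available that could explain this outcome.

Going by these compounds, a single methyl at a single position says little about other groups, so it remains open whether a methoxy group, an amine, a chlorine atom or a longer chain on this same carbon would also leave the number within the scatter. On these data alone, it also remains open whether methyl would give a similar result on the other aromatic carbons of this ring, or on a compound carrying a different group on the shared core.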